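The compounds below may be only part of what the source reports. "The series", "measured", "known", "first", "only" and "open" are said of these compounds alone.

Measured compounds:
`O=C(O)Cc1sc(C(c2ccc(F)cc2)c2ccc(F)cc2)nc1-c1ccco1` compound 1: 80%
`O=C(O)Cc1sc(CS(=O)(=O)c2ccc(Cl)cc2)nc1-c1ccc(Cl)cc1` compound 2: 30%

In an in vitro functional assay on HEK285-7 cells for antagonist activity at prostaglandin D2 receptor 2 (Homo sapiens), read by BRET and beta-arrestin recruitment (on this read-out higher numbers stand for larger maximal responses and lower numbers for smaller maximal responses), compound 1 gives 80%, the higher of the two numbers, and compound 2 gives 30%, a gap beyond the usual scatter. Compound 3, `O=C(O)Cc1sc(C(c2ccc(F)cc2)c2ccc(F)cc2)nc1-c1ccnc(O)c1`, is not yet measured. It differs from compound 1 in one place: 2-hydroxypyridin-4-yl in place of furan-2-yl on an aromatic carbon. Among the measured compounds shown here, no measured pair shows what this change does, so the expectation rests on compound 1 alone. The shift from compound 1 to compound 3 is expected to be small, within the scatter, giving an estimate for compound 3 of 75% (range 45% to 100%), an expected step of a number 5 percentage points lower from compound 1 to compound 3 (within the scatter).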

Compound 3, largest response reached (reported as efficacy), in percent of the reference or control that the assay uses: 60%
Compound 3: the middle estimate sits 15 percentage points above what was measured; the range from low to high includes it.
By their numbers in this assay, from the lowest: compound 2; then compound 3; then compound 1.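

In this assay, putting 2-hydroxypyridin-4-yl in place of furan-2-yl on the aromatic carbon next to the ring nitrogen gives a number 20 percentage points lower from compound 1 to compound 3 (beyond the scatter). Among the compounds shown here, this is the first change in one place alone, and it shows that the maximal response depends on the ring carried at this position. Nothing measured here accounts for the step.

Going by these compounds, the ring size, the ring nitrogen and the hydroxyl group all change at once, so their separate shares stay open. A plain phenyl ring or an unsubstituted pyridin-4-yl group here would help to separate them.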